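The source may report more compounds than this note shows. Statements on the series, on what has been measured and on what is new or still open speak of the compounds shown alone.

Measured so far in a functional assay on a cell-free system (plasma, Homo sapiens), with a stated time of 3 min; a lower number here means a stronger inhibitor, a higher number a weaker inhibitor:
- compound 1 `O=C(NCc1cc(Cl)ccc1-n1cnnn1)[C@@H]1C[C@@H]2C[C@@H]2N1C(=O)[C@H](O)c1cccc(Cl)c1` gives 1000 nM
- compound 2 `O=C(NCc1cc(Cl)ccc1-n1cnnn1)[C@@H]1[C@H]2C[C@H]2CN1C(=O)[C@H](O)c1ccccc1` gives 960 nM
- compound 3 `CC(C)(C)C[C@@H](O)C(=O)N1C[C@@H]2C[C@@H]2[C@H]1C(=O)NCc1cc(Cl)ccc1-n1cnnn1` gives 910 nM

These three values lie within the usual scatter of one another, so compound 3 stands level with compound 1 and compound 2. Compound 4 `O=C(NCc1cc(Cl)ccc1-n1cnnn1)[C@@H]1[C@H]2C[C@H]2CN1C(=O)[C@H](O)C1CCCCC1` carries cyclohexyl in place of neopentyl on a saturated chain carbon bound to a carbonyl carbon and an oxygen on a saturated carbon. For the measured compounds named here, one measured step bears on this place, neopentyl in place of phenyl, and it stayed within the scatter: a 1.1-fold lower number from compound 2 to compound 3 (0.02 log units; within the scatter). Going by the values given here, no measurement yet covers cyclohexyl, so a step beyond the scatter is not expected in this assay. The expected step is small: a 1.2-fold lower number from compound 3 to compound 4 (0.08 log units; within the scatter). For compound 4 the estimate is 750 nM, with an expected range from 250 nM to 1800 nM.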

Compound 4, half-maximal inhibitory concentration: 850 nM
For compound 4 the middle estimate is 1.1-fold (0.05 log units) below the measured one; the measured number falls inside the stated range.
By their numbers in this assay, from the lowest: compounds 4, 3, 2 and 1 (each within the scatter of the next).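

In this assay, the new ring adds a third kind of carbon group at this position, and the number still does not shift beyond the scatter. Cyclohexyl matches both neopentyl (a 1.1-fold lower number from compound 3 to compound 4 (0.03 log units; within the scatter)) and phenyl (a 1.1-fold lower number from compound 2 to compound 4 (0.05 log units; within the scatter)), so among these three groups, neither a six-membered non-aromatic ring nor its replacement by an open-chain group or phenyl separates the compounds. Nothing available explains this lack of difference. On these data alone, all three groups contain only carbon and hydrogen, so it remains open whether an amine or a carboxylic acid here would change the number beyond the scatter.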